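This account rests on a few compounds, and the source may have more. Where it says the series, first, only, none or still open, it means among the compounds named here.

Measured compounds in a functional assay on HeLa cells (Homo sapiens) for inhibition, read by sulforhodamine B assay; on this read-out lower numbers stand for stronger inhibition and higher numbers for weaker inhibition:
compound 1 `O=C1C(N2CCCCC2)=CC(=O)c2c1nc1n2[C@H]2OC[C@@H](O)[C@H]2OC1`: in this assay compound 1 gives only a limit, > 16000 nM.
compound 2 `CCCN(CCC)C1=CC(=O)c2c(nc3n2[C@H]2OC[C@@H](O)[C@H]2OC3)C1=O`: in this assay compound 2 also gives only a limit, > 16000 nM.

Compound 2 thus stands at the limit of this assay; the numbers place it no more finely. Compound 3 `O=C1C(Nc2ccc(I)cc2)=CC(=O)c2c1nc1n2[C@H]2OC[C@@H](O)[C@H]2OC1` differs from compound 2 by (4-iodophenyl)amino in place of dipropylamino on a double-bonded ring carbon. Going by the values given here, the single measured step, a step that the two limits leave unreadable from compound 1 to compound 2, bears on this change only in that both of its ends sit at the limit, as the limit of > 16000 nM in this assay, at which 2 of the 2 values shown sit, records, so its size is not readable. Among the compounds with values here, no measured step therefore sets a size or direction for the expected change in this assay. The estimate for compound 3 is 9000 nM, with a range from 1500 nM to 30000 nM. This corresponds to an expected step of an at least 1.7-fold lower number from compound 2 to compound 3 (0.24 log units; that floor lies within the scatter), most probably again reported as a limit.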

Compound 3, half-maximal inhibitory concentration: 4010 nM
Beside the measured number, compound 3's estimate is 2.2-fold (0.35 log units) above it, within the range that was stated.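

In this assay, the position on the double-bonded ring carbon proves able to give a value off the limit, with an at least 3.9-fold lower number from compound 2 to compound 3 (0.60 log units; beyond the scatter) and an at least 3.9-fold lower number from compound 1 to compound 3 (0.60 log units; beyond the scatter). The piperidin-1-yl and dipropylamino compounds gave no such reading. Both steps are floors rather than sizes, since compound 1 and compound 2 each carry only a limit: the limit of > 16000 nM in this assay, at which 2 of the 3 values shown sit.

On these data alone, the change brings in an aromatic ring, an iodine and a hydrogen-bond donor together, so their separate contributions remain open. Plain phenylamino, 4-chlorophenylamino or benzylamino at this carbon would bear on that question.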